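This account rests on a few compounds, and the source may have more. Where it says the series, first, only, none or still open, it means among the compounds named here.

Measured compounds in an ADME assay on Vero cells (Chlorocebus sabaeus) for cytotoxicity; a higher number here means that more compound is tolerated, a lower number that less compound is tolerated:
- compound 1, `O=C(CN1CCCC1)Nc1ccc(-c2nc3cc(C(F)(F)F)ccc3[nH]2)cc1`: > 100000 nM (a limit of the assay, not a number)
- compound 2, `O=C(CN1CCCC1)Nc1ccc(-c2nc3ccccc3[nH]2)cc1`: > 100000 nM (likewise a limit)

Compound 1 stands only at a limit in this assay. Among the compounds with values here, the sole measured step, a step that the two limits leave unreadable from compound 1 to compound 2, cannot be sized, since both ends of it sit at the limit of > 100000 nM in this assay, at which 2 of the 2 values shown sit; the one change explored on the shared core therefore gives no readable direction for cytotoxicity.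

Compound 3, `O=[N+]([O-])c1ccc(-c2nc3cc(C(F)(F)F)ccc3[nH]2)cc1`, has not yet been measured in this assay. Its difference from compound 1 is nitro in place of (((pyrrolidin-1-yl)methyl)carbonyl)amino on an aromatic carbon. No measured step touches this position, so nothing on the numbers shown speaks for or against a shift in cytotoxicity on going from compound 1 to compound 3; the only evidence is that every value so far sits at the limit.

On that basis compound 3 is expected to stay near the limit as well, with the step of a number no higher from compound 1 to compound 3 (the limit leaves the size open) estimated as no change beyond the scatter. The estimate for compound 3 in this assay is 100000 nM, within 30000 nM to 200000 nM, and the measurement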

Compound 3, half-maximal cytotoxic concentration: 45000 nM
For compound 3 the middle estimate is 2.2-fold (0.35 log units) above the measured one; low and high end bracket the measured number.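

Nitro in place of (((pyrrolidin-1-yl)methyl)carbonyl)amino gives an at least 2.2-fold lower number from compound 1 to compound 3 (0.34 log units; beyond the scatter) in this assay; this is the first step in the series that can be read, and it shows that a change at this aromatic carbon, para to a large group, can lower the tolerated concentration, which the unreadable exchange of trifluoromethyl for hydrogen could not show. Within the data shown here, compound 3, at 45000 nM, carries the first value that is a number. The full size of the step remains open because compound 1 stands at a limit: the limit of > 100000 nM in this assay, at which 2 of the 3 values shown sit.

The single exchange removes the whole (((pyrrolidin-1-yl)methyl)carbonyl)amino group and introduces nitro together, so the compounds shown cannot separate the effect of losing one from that of gaining the other; a primary amine, an acetylamino group or a carboxylic acid at this position would help to divide the two. Also open, going by these compounds, is whether trifluoromethyl matters once nitro is present, a question that the nitro compound with hydrogen in place of trifluoromethyl would address.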